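Swapping Propyl for Pyrazinyl on the Amide Nitrogen

The compounds below may be only part of what the source reports. "The series", "measured", "known", "first", "only" and "open" are said of these compounds alone.

Within the data shown here, compound 2 `CCCN(Cc1cccs1)C(=O)COc1ccc(C)cc1` gives the lowest number of the two measured so far in an assay on HEK293 cells for agonist activity at transient receptor potential cation channel subfamily M member 8 (Homo sapiens), read by fluorescence and calcium flux, with a stated time of 15 min (a higher number here means that more compound is needed for the effect, a lower number that less compound is needed), at 40 nM. Compound 1 `COCCN(Cc1cccs1)C(=O)COc1ccc(C)cc1` gives 400 nM in this assay, and the step of a 10-fold lower number from compound 1 to compound 2 (1.00 log units; beyond the scatter) lies at a different place in the molecule. Compound 3 `Cc1ccc(OCC(=O)N(Cc2cccs2)c2cnccn2)cc1` differs from compound 2 by pyrazin-2-yl in place of propyl on an amide-type nitrogen. Among the measured compounds shown here, no measured step touches this nitrogen, so the one known step bears little on it. The change is large, and a modestly higher number is expected for compound 3, a 3.8-fold higher number from compound 2 to compound 3 (0.57 log units; beyond the scatter). Compound 3 is therefore estimated at 150 nM, within 30 nM to 1000 nM.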

Compound 3, half-maximal effective concentration: 1240 nM
For compound 3 the middle estimate is 8.3-fold (0.92 log units) below the measured one; measured number outside the range, above it.
By their numbers in this assay, from the lowest: compound 2; then compound 1; then compound 3.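

Among these compounds, compound 3 puts an aromatic ring on the amide-type nitrogen for the first time, and in this assay pyrazin-2-yl in place of propyl gives a 31-fold higher number from compound 2 to compound 3 (1.49 log units; beyond the scatter). The same ring in place of 2-methoxyethyl gives a smaller change, a 3.1-fold higher number from compound 1 to compound 3 (0.49 log units; beyond the scatter), so both saturated chains give lower numbers here than this ring does. No evidence at hand accounts for these steps. On these data alone, how a phenyl ring or a longer chain such as butyl would fare on this nitrogen remains open.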